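Hydroxyphenyl position change on the shared core

The source may report more compounds than this note shows. Statements on the series, on what has been measured and on what is new or still open speak of the compounds shown alone.

Measured so far in an assay on cells for displacement of a labelled ligand from adenosine receptor A1 (Homo sapiens), read by scintillation counting and radioligand binding, with a stated time of 60 min; a lower number here means a stronger inhibitor, a higher number a weaker inhibitor:
compound 1 `CN1CCN(c2nc(-c3cc(Cl)ccc3Cl)nc3[nH]cnc23)CC1` gives 2510 nM
compound 2 `CN1CCN(c2nc(-c3cccc(O)c3)nc3[nH]cnc23)CC1` gives 158 nM

Compound 2 has the lowest of the two numbers in this assay; compound 1 stands higher by a 16-fold lower number from compound 1 to compound 2 (1.20 log units; beyond the scatter). Compound 3 `CN1CCN(c2nc(-c3ccc(O)cc3)nc3[nH]cnc23)CC1` differs from compound 2 as follows: 4-hydroxyphenyl in place of 3-hydroxyphenyl on an aromatic carbon. Among the measured compounds shown here, the only measured step, a 16-fold lower number from compound 1 to compound 2 (1.20 log units; beyond the scatter), concerns a different group and bears on this change only loosely. No step beyond the scatter is expected in this assay for compound 3, in either direction. Compound 3 is expected at 300 nM, within 60 nM to 1500 nM. The expected step is a 1.9-fold higher number from compound 2 to compound 3 (0.28 log units; within the scatter).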

Compound 3, inhibition constant: 398 nM
For compound 3 the middle estimate is 1.3-fold (0.12 log units) below the measured one; measured number inside the range.
By their numbers in this assay, from the lowest: compound 2; then compound 3; then compound 1.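

In this assay, 4-hydroxyphenyl in place of 3-hydroxyphenyl gives a 2.5-fold higher number from compound 2 to compound 3 (0.40 log units; beyond the scatter) with the same atoms, so where the hydroxy group sits on this phenyl ring changes the number. Both hydroxyphenyl compounds stand clear of the 2,5-dichlorophenyl compound, as 4-hydroxyphenyl also gives a 6.3-fold lower number from compound 1 to compound 3 (0.80 log units; beyond the scatter) and so the gain over the dichlorophenyl group does not depend on the 3-hydroxyphenyl arrangement alone. No measurement at hand accounts for the difference between the two hydroxyphenyl compounds.

On these data alone, whether a methoxyphenyl or an aminophenyl group at this place would follow the hydroxyphenyl numbers stays open. As far as these compounds go, whether the order of the two hydroxyphenyl groups holds with another amine in place of the 4-methylpiperazin-1-yl group is also open.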